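Dimethylamino for acetyl: two compounds measured, one pending

The source may report more compounds than this note shows. Statements on the series, on what has been measured and on what is new or still open speak of the compounds shown alone.

For the measured compounds named here, compound 1 `COc1cc(C)cc(-c2c(-c3ccnc(-c4ccc(C(C)=O)cc4)c3)cnn2CC#N)c1` stands lowest of the two numbers so far in a functional assay on SK-MEL-5 cells (Homo sapiens) for cytotoxicity, read by sulforhodamine B assay, with a stated time of 48 h, tested at 1 uM (a higher number here means a weaker effect of the compound at the concentration tested, a lower number a stronger effect), giving -37%. Going by the values given here, compound 2 `Cc1cc(O)cc(-c2nn(CC#N)cc2-c2ccnc(-c3ccc(N(C)C)cc3)c2)c1` gives -26% in this assay, a number higher than that of compound 1 by more than the usual scatter; the two differ in more than one place, so no single step is drawn from them. Compound 3 `COc1cc(C)cc(-c2c(-c3ccnc(-c4ccc(N(C)C)cc4)c3)cnn2CC#N)c1` is not yet measured. Relative to compound 1 it shows (dimethylamino in place of acetyl on an aromatic carbon). Compound 2 already carries dimethylamino and gives -26%, which argues against a large shift. The step of a number 7 percentage points higher from compound 1 to compound 3 (within the scatter) is expected to be a small rise, at most just beyond the scatter. Compound 3 is estimated at -30%, within a range from -50% to -10%.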

Compound 3, a percentage reported as activity, at one concentration (the size of the read-out at that concentration, not a potency): -31%
Compound 3: middle estimate off by 1 percentage points, on the high side; the measured number falls inside the stated range.
By their numbers in this assay, from the lowest: compounds 1, 3 and 2 (each within the scatter of the next, the first and the last beyond it).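

In this assay, for the compounds shown here, dimethylamino in place of acetyl on this aromatic carbon, para to a large group, gives the only single-place comparison so far: a number 6 percentage points higher from compound 1 to compound 3 (within the scatter). At this concentration the read-out therefore does not separate these two groups, each of 3 heavy atoms, on the shared core. No measurement shown bears on the reason for this result.

Going by these compounds, whether a primary amine or a carboxylic acid at this position would give a step beyond the scatter remains open. So does the outcome for a longer chain there.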